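Ester series on a shared lactone core: cytotoxicity notes

The source may hold more compounds than are shown below. What is called first, only, known or untested is meant among the compounds shown, and "the series" means these compounds.

The series keeps one core and varies the ester on the exocyclic oxygen. Compound 1 `CCCCCCCC(=O)OCc1cccc2c1CCOC2=O` carries an octanoate; in an ADME assay on HepG2 2.2.15 cells (Homo sapiens) for cytotoxicity, read by MTT assay, with a stated time of 72 h (on this read-out lower numbers stand for higher toxicity in this test and higher numbers for lower toxicity in this test), compound 1 gives only a limit, > 3450000 nM, so no number is known for it, and it sits at the limit of > 3450000 nM in this assay, at which 1 of the 3 values shown sits. Compound 2 `O=C(OCc1cccc2c1CCOC2=O)c1ccc([N+](=O)[O-])cc1`, the 4-nitrobenzoate, likewise returns only a limit in this assay, > 2260000 nM, which is the limit of > 2260000 nM in this assay, at which 1 of the 3 values shown sits. For the measured compounds named here, compound 3 `O=C(O)c1ccccc1C(=O)OCc1cccc2c1CCOC2=O`, the hemiphthalate bearing a free carboxylic acid, is the one member with a measured number: in this assay compound 3 gives 130000 nM. Compound 1 therefore stands with compound 2 at the top of the range, where the readout stops at a limit, while compound 3 lies lower.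

Compound 4 `O=C(OCc1cccc2c1CCOC2=O)c1cccnc1` is the nicotinate: pyridin-3-yl in place of heptyl on a carbonyl carbon. Going by the values given here, no measured step of this kind exists in the set. Since the aromatic ester compound 2 also gave a limit, compound 4 is expected to behave like compound 1 and compound 2, with no step beyond the scatter, and the step of an at least 1.1-fold lower number from compound 1 to compound 4 (0.06 log units; that floor lies within the scatter) is expected to be essentially flat. The expected value for compound 4 in this assay is 3000000 nM, within a range from 500000 nM to 10000000 nM, most likely again reported only as a limit.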

Compound 4, half-maximal cytotoxic concentration: > 2700000 nM
Compound 4: no number, only a limit; the forecaster's own chance of this, stated with the estimate: 70%; the middle value is on the limit's open side.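

Compound 1 and compound 4 both return only limits in this assay, so no step can be read from the change of heptyl to pyridin-3-yl on a carbonyl carbon. The compounds shown leave open where compound 1 and compound 4 truly lie in this assay, and whether this change shifts the read-out at all.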